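Dropping the chloro: a small change tested for cytotoxicity

The source may hold more compounds than are shown below. What is called first, only, known or untested is meant among the compounds shown, and "the series" means these compounds.

Of the compounds shown here, two share a core and have been tested in a functional assay on DLD-1 cells (Homo sapiens) for cytotoxicity, read by colorimetric assay and MTT assay, with a stated time of 3 days, tested at 20 uM; a lower number here means a stronger effect, a higher number a weaker effect of the compound at the concentration tested. Compound 1, `O=C1COc2ccc(-c3nn(-c4ccc(Cl)cc4)cc3-c3ccccc3)cc2N1`, gives 47.1% in this assay. Compound 2, `O=C1COc2ccc(-c3[nH]c(-c4c[nH]c5ncccc45)nc3-c3ccccc3)cc2N1`, gives 53.5% in this assay. Compound 1 has the lower of the two numbers, yet its gap to compound 2 lies within the scatter, so the two cannot be told apart on these data.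

Compound 3, `O=C1COc2ccc(-c3nn(-c4ccccc4)cc3-c3ccccc3)cc2N1`, has not been measured. It differs from compound 1 in one place: hydrogen in place of chloro on an aromatic carbon. The group that leaves is a single chlorine atom, and a hydrogen atom takes its place on the 4-chlorophenyl ring, turning it into a plain phenyl ring.

For the measured compounds named here, no measured pair shows what this change does in this assay, so the expectation rests only on the small size of the change. The step of a number 7.9 percentage points higher from compound 1 to compound 3 (within the scatter) is expected to be small and not beyond the scatter, if anything toward a slightly higher number. Compound 3 is therefore estimated at 55%, with a range from 35% to 75%.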

Compound 3, a percentage reported as activity, at one concentration (the size of the read-out at that concentration, not a potency): 47.7%
Beside the measured number, compound 3's estimate is 7.3 percentage points above it, within the range that was stated.
By their numbers in this assay, from the lowest: compounds 1, 3 and 2 (each within the scatter of the next).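

In this assay, for the compounds shown here, hydrogen in place of chloro gives the first pair of compounds that differ in one place, and it reads a number 0.6 percentage points higher from compound 1 to compound 3 (within the scatter). At this position, on an aromatic carbon para to a large group, the 4-chlorophenyl and plain phenyl rings therefore cannot be told apart by this read-out, so the chlorine atom makes no measurable difference here. Nothing available explains this result, and a single pair cannot show whether the same would hold on another core.

The compounds shown leave open whether a different group on this carbon, such as a methoxy group, an amine or a carboxylic acid, would shift the number beyond the scatter, or whether this position tolerates change more generally. They also leave open whether compound 1 and compound 3 would stay this close at other concentrations, as each value is the size of the effect at one concentration and not a potency.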